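A few compounds are considered here, and "the series" means these few. Any claim that something is new, unique, unknown or untested is made for them only; others in the source may bear on it.

Measured so far:
Compound 1 `N=C(N)N/N=C/c1c(-c2cc(Cl)sc2Cl)nc2n1CCS2`: 20400 nM
Compound 2 `Cc1cc(-c2nc3n(c2/C=N/NC(=N)N)CCS3)c(C)s1`: 29500 nM

In a functional assay on cells (Melanoma cell, Homo sapiens) for inhibition (a lower number here means a stronger inhibitor of growth, a higher number a weaker inhibitor of growth), compound 2 gives 29500 nM, and compound 1 gives 20400 nM. For the measured compounds named here, these are the only two numbers available, and they lie within the usual scatter of each other, so they cannot be ranked.

Compound 3 `N=C(N)N/N=C/c1c(-c2cccs2)nc2n1CCS2` has not yet been measured. Its structure differs from that of compound 2 in one group: thiophen-2-yl in place of 2,5-dimethylthiophen-3-yl on an aromatic carbon. The new group sits on an aromatic carbon of a five-membered aromatic ring with 2 nitrogen, at the same place as the group it replaces.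

Going by the values given here, only one measured step bears on this change: a 1.4-fold higher number from compound 1 to compound 2 (0.16 log units; within the scatter). That step also swaps one thiophene group for another at this place, and it stays within the scatter. Among the compounds with values here, it is a thin guide, since no measured compound carries thiophen-2-yl. Still, no step beyond the scatter is expected in this assay, and no direction can be called with confidence.

The expected size of the change is a 1.2-fold lower number from compound 2 to compound 3 (0.07 log units; within the scatter). For compound 3 the estimated value is 25000 nM, with an expected range of 12000 nM to 52000 nM.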

Compound 3, concentration for total growth inhibition: 38000 nM
For compound 3 the middle estimate is 1.5-fold (0.18 log units) below the measured one; the measured number falls inside the stated range.
By their numbers in this assay, from the lowest: compounds 1, 2 and 3 (each within the scatter of the next).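

In this assay, thiophen-2-yl carries neither the two methyl groups of compound 2 nor the two chlorines of compound 1, yet the change gives a 1.3-fold higher number from compound 2 to compound 3 (0.11 log units; within the scatter) and a 1.9-fold higher number from compound 1 to compound 3 (0.27 log units; within the scatter) as its two steps. Both are within the scatter, so the three thiophene groups at this place, on an aromatic carbon next to the ring nitrogen, cannot be told apart by their numbers. The change from a 3-yl to a 2-yl attachment and the loss of both ring substituents, taken together, therefore produce no readable difference here, although nothing measured explains why.

As far as these compounds go, these steps change the attachment and the substituents at once, so the effect of each alone stays unknown, and plain thiophen-3-yl would be needed to separate them. All three compounds also carry a thiophene at this place, which leaves open whether a phenyl ring, a simple amine, a carboxylic acid or a longer alkyl chain there would give a number clearly different from these.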